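The source may report more compounds than this note shows. Statements on the series, on what has been measured and on what is new or still open speak of the compounds shown alone.

Compound 2 `CC(=O)Oc1ccc(-c2ccc(F)cc2F)cc1C(=O)NC1CCCCC1` has the lowest number of the three in a functional assay on the whole organism (Ear) for inhibition, with Mus musculus as the target, at a dose of 40 mg/kg by the oral route; on this read-out lower numbers stand for less inhibition and higher numbers for more inhibition at the one dose given (going by the name of the read-out): compound 2 gives 0%, whereas compound 1 `CC(=O)Oc1ccc(-c2ccc(F)cc2F)cc1C(=O)O` gives 13.7% and compound 3 `CC(=O)Oc1ccc(-c2ccc(F)cc2F)cc1C(=O)Nc1ccccc1C` gives 19.6%. Compound 4 `CC(=O)Oc1ccc(-c2ccc(F)cc2F)cc1C(=O)Nc1ccc(Cl)cc1` differs from compound 2 by 4-chlorophenyl in place of cyclohexyl on an amide-type nitrogen. Going by the values given here, one measured step bears directly on this change, the replacement of cyclohexyl on the same amide-type nitrogen by an aromatic ring: a number 19.6 percentage points higher from compound 2 to compound 3 (beyond the scatter). The two steps from compound 1, a number 13.7 percentage points lower from compound 1 to compound 2 (beyond the scatter) and a number 5.9 percentage points higher from compound 1 to compound 3 (within the scatter), point the same way, the aromatic amide standing higher than the cyclohexyl one. A modest rise of similar direction is therefore expected: a number 15 percentage points higher from compound 2 to compound 4 (beyond the scatter). Compound 4 is estimated at 15%, within a range from 0% to 35%.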

Compound 4, a percentage reported as inhibition, in the whole organism at one dose (the size of the read-out at that dose, not a potency): 0%
Estimate against measurement, compound 4: 15 percentage points above; the measured number falls inside the stated range.
By their numbers in this assay, from the lowest: compounds 2 and 4 (each within the scatter of the next); then compounds 1 and 3 (each within the scatter of the next).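

In this assay, an aromatic ring on the amide-type nitrogen does not by itself raise the number, as no change at the digits printed from compound 2 to compound 4 (within the scatter) shows. The two aromatic amides separate instead, with a number 19.6 percentage points lower from compound 3 to compound 4 (beyond the scatter), so in these compounds the identity of the aromatic group counts, not just its presence, and a number 13.7 percentage points lower from compound 1 to compound 4 (beyond the scatter) places (4-chlorophenyl)amino below hydroxy on the carbonyl carbon. No measurement shown here explains this difference. Whether the chlorine, its place on the ring or the missing methyl accounts for the gap stays open; phenyl or 4-methylphenyl on the same nitrogen would help separate these.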